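This account rests on a few compounds, and the source may have more. Where it says the series, first, only, none or still open, it means among the compounds named here.

Three compounds share one core and differ only in the group attached to the carbonyl carbon. In a functional assay on the whole organism (strain Wistar) for inhibition, with Rattus norvegicus as the target, read by paw edema, with stated times of 60 min and 2 h, at a dose of 100 mg/kg by the oral route (a higher number here means more inhibition at the dose given (going by the name of the read-out), a lower number less inhibition), compound 1 `COc1cc2c(cc1OC)C(CC(=O)O)CC2` gives 24%. Compound 2 `CNC(=O)CC1CCc2cc(OC)c(OC)cc21` gives 30%, and compound 3 `COc1cc2c(cc1OC)C(CC(=O)N(C)C)CC2` gives 36%, the highest of the three numbers, although only a number 12 percentage points higher from compound 1 to compound 3 (beyond the scatter) lies beyond the scatter, while a number 6 percentage points higher from compound 2 to compound 3 (within the scatter) does not. Compound 4 `COc1cc2c(cc1OC)C(CC(=O)NC1CCCCC1)CC2` differs from compound 3 by cyclohexylamino in place of dimethylamino on a carbonyl carbon. The relevant measured steps are a number 6 percentage points higher from compound 1 to compound 2 (within the scatter) and a number 6 percentage points higher from compound 2 to compound 3 (within the scatter), both small, so changing the amide substituent has so far moved the read-out little. In this assay compound 4 is therefore expected to give about 35%, within a range from 20% to 50%. This estimate means an expected step of a number 1 percentage points lower from compound 3 to compound 4 (within the scatter), within the scatter.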

Compound 4, a percentage reported as inhibition, in the whole organism at one dose (the size of the read-out at that dose, not a potency): 56%
Estimate against measurement, compound 4: 21 percentage points below; the measured number lies above the stated range.
By their numbers in this assay, from the lowest: compounds 1, 2 and 3 (each within the scatter of the next, the first and the last beyond it); then compound 4.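

In this assay the group on the carbonyl carbon can move the read-out well beyond the scatter: cyclohexylamino in place of dimethylamino gives a number 20 percentage points higher from compound 3 to compound 4 (beyond the scatter) and cyclohexylamino in place of hydroxy gives a number 32 percentage points higher from compound 1 to compound 4 (beyond the scatter) on the same core. Cyclohexyl in place of methyl on the amide nitrogen, with the amide hydrogen present on both sides, gives a number 26 percentage points higher from compound 2 to compound 4 (beyond the scatter) in the same read-out, so that hydrogen alone does not set compound 4 apart. Nothing measured here explains the rise.

As far as these compounds go, it remains open whether a cyclopentyl ring, a phenyl ring or an open hexyl chain on the amide nitrogen would do the same. A methyl on the amide nitrogen of compound 4 would show whether the amide hydrogen is needed at all.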